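The source may report more compounds than this note shows. Statements on the series, on what has been measured and on what is new or still open speak of the compounds shown alone.

Measured so far:
- compound 1, `c1ccc(-c2cnc(Cn3ccnc3)cn2)cc1`: 610 nM
- compound 2, `c1ccc(-c2ccc(Cc3cccnc3)cn2)cc1`: 32 nM

In an in vitro assay on V79MZh cells for inhibition of cytochrome P450 11B1, mitochondrial (Homo sapiens) (on this read-out lower numbers stand for stronger inhibition and higher numbers for weaker inhibition), compound 2 gives 32 nM, the lower of the two numbers in hand. Compound 1 gives 610 nM in this assay, a higher number, and the gap between the two lies beyond the usual scatter. The two differ in several places at once, so no single structural step can be read from that gap.

Compound 3, `c1ccc(-c2ccc(Cc3ccncc3)cn2)cc1`, has not been measured in this assay. It is built from compound 2 by one change: pyridin-4-yl in place of pyridin-3-yl on a saturated chain carbon bound to an aromatic carbon. Both groups carry the same ring size and the same count of ring hetero atoms; only the point of attachment moves. Within the data shown here, no pair of measured compounds shows what such a move does in this assay, so the expected size of the step rests on the small nature of the change alone. A change of this kind is expected to stay within, or close to, the scatter, in either direction.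

For compound 3 in this assay the estimate is 50 nM, in the range 10 nM to 250 nM, which would mean a step of a 1.6-fold higher number from compound 2 to compound 3 (0.19 log units; within the scatter) and is expected to leave compound 3 near compound 2.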

Compound 3, half-maximal inhibitory concentration: 98 nM
The estimate for compound 3 lay 2.0-fold (0.29 log units) below the measured number; the measured number falls inside the stated range.
By their numbers in this assay, from the lowest: compound 2; then compound 3; then compound 1.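

In this assay, moving only the point of attachment, with pyridin-4-yl in place of pyridin-3-yl on a saturated chain carbon bound to an aromatic carbon, gives a 3.1-fold higher number from compound 2 to compound 3 (0.49 log units; beyond the scatter). This position therefore responds to where the ring is attached, even though both groups have the same heavy atoms, ring size and counts of hydrogen-bond donors and acceptors. This is the only single-place step among the compounds shown, and it reveals a direction, towards weaker inhibition, that the gap between compound 1 and compound 2, spread over several places, could not assign to any one change; no measurement available here accounts for the size of this step.

Still open, as far as these compounds go, is whether pyridin-2-yl on the same chain carbon, or a saturated amine such as morpholin-4-yl, would give a number nearer to that of compound 2 or that of compound 3. Also open, from the compounds shown here alone, is whether the same move from pyridin-3-yl to pyridin-4-yl would produce a step of similar size and direction on a different core, as one pair cannot establish a trend for the series.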